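The source may hold more compounds than are shown below. What is called first, only, known or untested is meant among the compounds shown, and "the series" means these compounds.

Values in a functional assay on the whole organism with Rattus norvegicus as the target; on this read-out lower numbers stand for an effect already at smaller amounts and higher numbers for an effect only at larger amounts of compound:
- Compound 1 `COC(=O)Cn1c(=N)sc2cc(OC(F)(F)F)ccc21`: > 10 mg/kg, a limit
- Compound 2 `N=c1sc2cc(OC(F)(F)F)ccc2n1CCS(=O)(=O)O`: > 10 mg/kg, a limit
- Compound 3 `N=c1sc2cc(OC(F)(F)F)ccc2n1CCO`: 8 mg/kg

Among the compounds with values here, compound 3, at 8 mg/kg, holds the only actual number in this small set. Compound 1 and compound 2 stand at the limit of > 10 mg/kg in this assay, at which 2 of the 3 values shown sit.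

Compound 4 `CSCn1c(=N)sc2cc(OC(F)(F)F)ccc21` has methylsulfanyl in place of hydroxymethyl on a saturated chain carbon bound to an aromatic nitrogen. Within the data shown here, two measured steps bear on this change, as both lead to the hydroxymethyl of compound 3: an at least 1.2-fold lower number from compound 1 to compound 3 (0.09 log units; that floor lies within the scatter) and an at least 1.2-fold lower number from compound 2 to compound 3 (0.09 log units; that floor lies within the scatter). Each gives only a floor, so neither shows a real change. The expected result is therefore a 1.3-fold higher number from compound 3 to compound 4 (0.10 log units; within the scatter), with no shift beyond the scatter. Compound 4 is estimated at 10 mg/kg, within a range of 4 mg/kg to 25 mg/kg.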

Compound 4, dose for half-maximal effect: 3 mg/kg
Estimate against measurement, compound 4: 3.3-fold (0.52 log units) above; measured number outside the range, below it.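

In this assay, this place on a saturated chain carbon bound to an aromatic nitrogen now shows a change beyond the scatter: methylsulfanyl in place of hydroxymethyl gives a 2.7-fold lower number from compound 3 to compound 4 (0.43 log units; beyond the scatter). The same group also gives an at least 3.3-fold lower number from compound 2 to compound 4 (0.52 log units; beyond the scatter) and an at least 3.3-fold lower number from compound 1 to compound 4 (0.52 log units; beyond the scatter). Those last two steps are only floors, set by a limit: the limit of > 10 mg/kg in this assay, at which 2 of the 4 values shown sit. The change to compound 4 swaps oxygen for sulfur and loses the hydrogen-bond donor together, so the compounds shown cannot separate the two. On these data alone, whether methoxymethyl or a longer chain such as ethylsulfanyl would fit this trend remains open.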